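Swapping the aryloxy group for fluoro: half-life expectations

The source may hold more compounds than are shown below. What is called first, only, known or untested is meant among the compounds shown, and "the series" means these compounds.

Measured compounds:
Compound 1 `C=CC(=O)NCc1coc(-c2c(N)ncnc2Nc2ccc(Oc3cc(Cl)ccc3Cl)c(Cl)c2)n1` gives 0.95 h in an in vitro ADME assay on microsomes from liver (Mus musculus) for metabolic stability, tested at 5 uM; on this read-out lower numbers stand for a shorter-lived compound and higher numbers for a longer-lived compound.
Compound 2 `C=CC(=O)NCc1coc(-c2c(N)ncnc2Nc2ccc(Oc3cccc(F)c3)c(Cl)c2)n1` gives > 1.66 h in this assay; this value is a limit of the assay (the limit of > 1.66 h in this assay, at which 1 of the 3 values shown sits).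
Compound 3 `C=CC(=O)NCc1coc(-c2c(N)ncnc2Nc2ccc(Oc3cccnc3)c(Cl)c2)n1` gives 0.3 h in this assay.

Compound 3 stands lowest among the numbers shown; its nearest neighbour is compound 1, and the step of a 3.2-fold lower number from compound 1 to compound 3 (0.50 log units; beyond the scatter) lies beyond the scatter. The step of an at least 5.5-fold lower number from compound 2 to compound 3 (0.74 log units; beyond the scatter) is larger still, while an at least 1.7-fold higher number from compound 1 to compound 2 (0.24 log units; that floor lies within the scatter) has its floor within the scatter.

Compound 4 `C=CC(=O)NCc1coc(-c2c(N)ncnc2Nc2ccc(F)c(Cl)c2)n1` differs from compound 3 by fluoro in place of (pyridin-3-yl)oxy on an aromatic carbon. Among the measured compounds shown here, no measured step removes the aryloxy group altogether, so only the steps into compound 3 bear on it: both a 3.2-fold lower number from compound 1 to compound 3 (0.50 log units; beyond the scatter) and an at least 5.5-fold lower number from compound 2 to compound 3 (0.74 log units; beyond the scatter) show that the pyridin-3-yloxy partner sits at the short-lived end of this small set. Taking the pyridin-3-yloxy group away and leaving a fluoro is therefore expected to move compound 4 back upward, toward the half-life of compound 1, with considerable uncertainty. The expected step is a 3.0-fold higher number from compound 3 to compound 4 (0.48 log units; beyond the scatter). For compound 4 the estimate is 0.9 h, within a range of 0.35 h to 2 h.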

Compound 4, half-life: 0.15 h
Beside the measured number, compound 4's estimate is 6.0-fold (0.78 log units) above it; measured number outside the range, below it.
By their numbers in this assay, from the lowest: compounds 4 and 3 (each within the scatter of the next); then compound 1. At a limit, above all of these: compound 2.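

Taking away the whole aromatic ring does not lengthen the half-life in this assay: the step is a 2.0-fold lower number from compound 3 to compound 4 (0.30 log units; within the scatter), so on this aromatic carbon fluoro and (pyridin-3-yl)oxy cannot be told apart, and a smaller group alone does not bring back the half-life of the phenoxy compounds. Against those phenoxy compounds the loss is clear, with a 6.3-fold lower number from compound 1 to compound 4 (0.80 log units; beyond the scatter) and an at least 11-fold lower number from compound 2 to compound 4 (1.04 log units; beyond the scatter), so among the compounds shown the longer half-lives go with the 2,5-dichlorophenoxy and 3-fluorophenoxy groups, while compound 3 shows that an aryloxy group at this place does not suffice by itself. The number for compound 2 is a limit of the assay, which leaves the full size of its step unfixed: the limit of > 1.66 h in this assay, at which 1 of the 4 values shown sits.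

From the compounds shown here alone, what stays open is whether the longer half-lives follow the phenyl ring itself or the halogens on it, which an unsubstituted phenoxy group would help to separate. Going by these compounds, it is also open how other small groups on this carbon, such as a methoxy group, an amine or a nitrile, would compare with fluoro.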